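A second methoxy on compound 3

A few compounds are considered here, and "the series" means these few. Any claim that something is new, unique, unknown or untested is made for them only; others in the source may bear on it.

Values measured so far in an ADME assay on Vero cells (Chlorocebus sabaeus) for cytotoxicity, read by resazurin assay, with a stated time of 72 h (on this read-out higher numbers stand for weaker inhibition and lower numbers for stronger inhibition), are these:
- compound 1 `Cc1ccc(C(=O)CCN2CCN(c3ccc([N+](=O)[O-])cc3)CC2)cc1` gives 235000 nM
- compound 2 `COc1ccc(C(=O)CCN2CCN(c3ccc(Cl)cc3)CC2)cc1` gives 300000 nM
- compound 3 `COc1ccc(C(=O)CCN2CCN(c3ccc([N+](=O)[O-])cc3)CC2)cc1` gives 587000 nM

Compound 3 sits at the upper end of this small set. The step of a 2.0-fold higher number from compound 2 to compound 3 (0.29 log units; within the scatter) gives no real separation, while the step of a 2.5-fold higher number from compound 1 to compound 3 (0.40 log units; beyond the scatter) does, though only modestly.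

Compound 4 `COc1ccc(C(=O)CCN2CCN(c3ccc([N+](=O)[O-])cc3)CC2)cc1OC` takes methoxy in place of hydrogen on an aromatic carbon of compound 3, ortho to a methoxy group (methoxy in place of hydrogen on an aromatic carbon). For the measured compounds named here, no measured step adds a group where a hydrogen stood, so the evidence is indirect. The closest case is the modest step of a 2.5-fold higher number from compound 1 to compound 3 (0.40 log units; beyond the scatter) which swaps methyl for methoxy on an aromatic carbon. The other step, a 2.0-fold higher number from compound 2 to compound 3 (0.29 log units; within the scatter) swaps chloro for nitro and stays within the scatter. With steps this small, no change beyond the scatter is expected in this assay and the data favour no direction. That expectation amounts to a 1.2-fold lower number from compound 3 to compound 4 (0.07 log units; within the scatter) and nothing larger. Compound 4 is estimated at 500000 nM with an expected range from 250000 nM to 1000000 nM on this reading.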

Compound 4, half-maximal inhibitory concentration: 105000 nM
For compound 4 the middle estimate is 4.8-fold (0.68 log units) above the measured one, outside the stated range (below it).
By their numbers in this assay, from the lowest: compound 4; then compounds 1, 2 and 3 (each within the scatter of the next, the first and the last beyond it).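

In this assay a methoxy placed on an aromatic carbon, ortho to a methoxy group, gives a 5.6-fold lower number from compound 3 to compound 4 (0.75 log units; beyond the scatter) and so shows that this part of the ring responds to a new group, with the number moving toward stronger inhibition. For the compounds shown here, this is the first step here in which a group enters where a hydrogen stood, rather than one group replacing another. No measurement is available that would explain the shift.

From the compounds shown here alone, whether the shift belongs to methoxy itself or would follow any group at this place stays open, and an amine or a carboxylic acid there could help separate the two. Going by these compounds, it is also open whether the same addition would act alike on compound 2, which carries chloro where compound 3 carries nitro.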